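Moving the trifluoromethyl group on a shared biaryl core

The compounds below may be only part of what the source reports. "The series", "measured", "known", "first", "only" and "open" are said of these compounds alone.

For the measured compounds named here, compound 3, `Oc1ccc(-c2cc(-c3ccccc3C(F)(F)F)cc(-c3ccccc3O)n2)cc1`, is the only member of this small set for which a functional assay on DU-145 cells (Homo sapiens) for inhibition (on this read-out lower numbers stand for stronger inhibition and higher numbers for weaker inhibition), returns a number: compound 3 gives 6690 nM. Compound 1, `Oc1ccc(-c2cc(-c3ccccc3F)cc(-c3ccccc3O)n2)cc1`, sits at a limit of this assay, > 50000 nM, rather than at a number. Compound 2, `Oc1ccccc1-c1cc(-c2cccc(C(F)(F)F)c2)cc(-c2ccccc2O)n1`, likewise sits at a limit, > 50000 nM. Going by the values given here, the one measured step runs from compound 1 to compound 3 and amounts to an at least 7.4-fold lower number from compound 1 to compound 3 (0.87 log units; beyond the scatter), a change that carries the pair out of the limit of > 50000 nM in this assay, at which 2 of the 3 values shown sit, and into the measurable range.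

Compound 4, `Oc1ccc(-c2cc(-c3cccc(C(F)(F)F)c3)cc(-c3ccccc3O)n2)cc1`, differs from compound 3 only in the position of that same substituent: 3-(trifluoromethyl)phenyl in place of 2-(trifluoromethyl)phenyl on an aromatic carbon. Among the compounds with values here, no measured step covers this rearrangement directly. Compound 2 carries the 3-(trifluoromethyl)phenyl group as well and remains at its limit, which gives no support for expecting the number to fall. Compound 4 is therefore expected to be weaker in this assay, with a step of a 3.7-fold higher number from compound 3 to compound 4 (0.57 log units; beyond the scatter), and its estimated value is 25000 nM, within a range from 6000 nM to 100000 nM.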

Compound 4, half-maximal inhibitory concentration: > 50000 nM
Compound 4: only a limit was reported; the forecaster's own chance of this, stated with the estimate: 45%; at least 2.0-fold (0.30 log units) between middle value and limit.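

In this assay, 3-(trifluoromethyl)phenyl in place of 2-(trifluoromethyl)phenyl gives an at least 7.4-fold higher number from compound 3 to compound 4 (0.87 log units; beyond the scatter). Compound 4 has the same atoms as compound 3, so this step shows that where the trifluoromethyl group sits on that phenyl ring matters on this core, and that the group's presence alone does not yield a measurable number. The result for compound 4 is a limit and not a number, and it joins the other limits in the set: the limit of > 50000 nM in this assay, at which 3 of the 4 values shown sit.

The steps to compound 4 from compound 1 and from compound 2 cannot be read, as each joins two limits. The compounds shown also leave open how an amine or a carboxylic acid in place of the trifluoromethyl group of compound 3 would read out in this assay.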